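A Phenoxy Group in Place of Hydrogen on the Anilide

The compounds below may be only part of what the source reports. "The series", "measured", "known", "first", "only" and "open" are said of these compounds alone.

Compound 2 `O=C(Nc1ccccc1)[C@@H]1CCCN1C(=O)CSc1nc2ccccc2[nH]1` gives 560 nM in an assay on CHO cells for displacement of a labelled ligand from Orexin receptor type 2 (Homo sapiens) (a higher number here means a weaker inhibitor, a lower number a stronger inhibitor), the highest number of the two measured compounds. Compound 1 `O=C(Nc1ccccc1-c1ccccc1)[C@@H]1CCCN1C(=O)CSc1nc2ccccc2[nH]1` gives 0.6 nM in this assay. Going by the values given here, the single measured step, a 930-fold higher number from compound 1 to compound 2 (2.97 log units; beyond the scatter), shows how much is lost when the phenyl is removed. Compound 3 `O=C(Nc1ccccc1Oc1ccccc1)[C@@H]1CCCN1C(=O)CSc1nc2ccccc2[nH]1` makes a related change: phenoxy in place of hydrogen on an aromatic carbon. Because a 930-fold higher number from compound 1 to compound 2 (2.97 log units; beyond the scatter) was large, a large fall in the number is expected for compound 3, a step of about a 280-fold lower number from compound 2 to compound 3 (2.45 log units; beyond the scatter). Compound 3 is therefore estimated at 2 nM in this assay, within a range from 0.3 nM to 15 nM.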

Compound 3, inhibition constant: 3 nM
Beside the measured number, compound 3's estimate is 1.5-fold (0.18 log units) below it; the measured number falls inside the stated range.
By their numbers in this assay, from the lowest: compound 1; then compound 3; then compound 2.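

In this assay the gain at this position does not depend on a phenyl attached directly to the ring: phenoxy also brings a 190-fold lower number from compound 2 to compound 3 (2.27 log units; beyond the scatter) and so recovers most of what compound 2 lacks. Phenoxy and phenyl are still not equal here, since replacing one with the other gives a 5.0-fold higher number from compound 1 to compound 3 (0.70 log units; beyond the scatter) and that gap is modest. Nothing available explains either step. From the compounds shown here alone, whether an aromatic ring is needed at all remains open. A methoxy group, a benzyl group or an amine at this position could help to show how much of the gain depends on that ring.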